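From isopropyl to (oxan-4-yl)methyl on an aromatic nitrogen

This account rests on a few compounds, and the source may have more. Where it says the series, first, only, none or still open, it means among the compounds named here.

Values measured in a functional assay on MKN-45 cells (Homo sapiens) for antiproliferative activity, with a stated time of 72 h (on this read-out higher numbers stand for weaker inhibition and lower numbers for stronger inhibition), are these:
- Compound 1 `Cn1cc(-c2cc(F)c(NC(=O)c3cn(CC4CCOCC4)cc(-c4ccc(F)cc4)c3=O)cc2F)c2c(N)ncnc21` gives 53.7 nM here
- Compound 2 `CN(C)C(=O)Cn1cc(C(=O)Nc2ccc(-c3cn(C)c4ncnc(N)c34)cc2)c(=O)c(-c2ccc(F)cc2)c1` gives > 100 nM as a limit of the assay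
- Compound 3 `CC(C)n1cc(C(=O)Nc2cc(F)c(-c3c[nH]c4ncnc(N)c34)cc2F)c(=O)c(-c2ccc(F)cc2)c1` gives 13.2 nM here

Compound 3 holds the lower of the two actual numbers, and compound 1 stands above it by a gap beyond the usual scatter. The value of compound 2 is a limit and not a number, so it cannot be placed exactly.

Compound 4 `Nc1ncnc2[nH]cc(-c3cc(F)c(NC(=O)c4cn(CC5CCOCC5)cc(-c5ccc(F)cc5)c4=O)cc3F)c12` has not yet been measured. It carries (oxan-4-yl)methyl in place of isopropyl on an aromatic nitrogen, set against compound 3 (oxan-4-yl)methyl in place of isopropyl on an aromatic nitrogen and otherwise unchanged. Compound 1 also carries (oxan-4-yl)methyl on an aromatic nitrogen and gives 53.7 nM in this assay so some loss of strength is expected. The expected step is a 1.9-fold higher number from compound 3 to compound 4 (0.28 log units; within the scatter) towards weaker inhibition, small and not clearly beyond the scatter. For compound 4 the estimate is 25 nM with an expected range from 8 nM to 70 nM in this measurement.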

Compound 4, half-maximal inhibitory concentration: 29.8 nM
Beside the measured number, compound 4's estimate is 1.2-fold (0.08 log units) below it, within the range that was stated.
By their numbers in this assay, from the lowest: compound 3; then compounds 4 and 1 (each within the scatter of the next). At a limit, above all of these: compound 2.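

In this assay, this pair sets (oxan-4-yl)methyl directly against isopropyl on the aromatic nitrogen with the rest of the compound unchanged, and the exchange brings a 2.3-fold higher number from compound 3 to compound 4 (0.35 log units; beyond the scatter) as a modest weakening. The position therefore accepts the ring-bearing group, which has more heavy atoms and a hydrogen-bond acceptor, and inhibition stays in the same general range. With (oxan-4-yl)methyl held in place, hydrogen in place of methyl on the other aromatic nitrogen gives a 1.8-fold lower number from compound 1 to compound 4 (0.26 log units; within the scatter), so that change cannot be told apart from the scatter, and nothing shown here offers a cause for either step.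

The compounds shown leave open whether the ring oxygen matters, as a cyclohexylmethyl group would test. They also leave open how an amine or a carboxylic acid at the end of a longer chain on this nitrogen would compare with compound 3 and compound 4.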